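This account rests on a few compounds, and the source may have more. Where it says the series, first, only, none or still open, it means among the compounds named here.

Measured in a functional assay on HCT-116 cells (Homo sapiens) for inhibition, read by sulforhodamine B assay, with a stated time of 48 h, tested at 50 uM; on this read-out lower numbers stand for less inhibition of growth and higher numbers for more inhibition of growth at the one concentration tested:
- compound 1 `COc1ccc([C@@H]2C/C(=N/OCc3cn(-c4ccc(C(=O)c5ccccc5)cc4)nn3)c3cc(CC=C(C)C)c(OC)cc3O2)cc1` gives 52%
- compound 2 `COc1ccc([C@@H]2C/C(=N/OCc3cn(-c4ccc(C#N)cc4)nn3)c3cc(CC=C(C)C)c(OC)cc3O2)cc1` gives 50%
- compound 3 `COc1cc2c(cc1CC=C(C)C)[C@H](O)C[C@@H](c1ccc(O)cc1)O2` gives 37%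

Compound 2 at 50% sits level with compound 1 within the scatter and clearly above compound 3 at 37%. The next analogue is compound 4 `COc1ccc([C@@H]2C/C(=N/OCc3cn(-c4cc(OC)c(OC)c(OC)c4)nn3)c3cc(CC=C(C)C)c(OC)cc3O2)cc1`, with the change (3,4,5-trimethoxyphenyl in place of 4-cyanophenyl on an aromatic nitrogen), that is, 3,4,5-trimethoxyphenyl in place of 4-cyanophenyl on an aromatic nitrogen. For the measured compounds named here, one measured step bears on this: a number 2 percentage points lower from compound 1 to compound 2 (within the scatter). It alters a group on the same aromatic ring but does not replace the whole ring, so it is only a loose guide. In this assay the expected change is none beyond the scatter, with an estimated a number 2 percentage points higher from compound 2 to compound 4 (within the scatter). Compound 4 is expected at 52%, with an estimated range of 38% to 67%.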

Compound 4, percent growth inhibition at one concentration: 29%
For compound 4 the middle estimate is 23 percentage points above the measured one; measured number below the stated range.
By their numbers in this assay, from the lowest: compounds 4 and 3 (each within the scatter of the next); then compounds 2 and 1 (each within the scatter of the next).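

In this assay, exchanging the group on the aromatic nitrogen gives a number 21 percentage points lower from compound 2 to compound 4 (beyond the scatter), so the aryl group at this position can shift growth inhibition beyond the scatter. The earlier change on this ring, a number 2 percentage points lower from compound 1 to compound 2 (within the scatter), did not show this. Nothing available explains the drop. Open, as far as these compounds go, is whether the drop belongs to the three methoxy groups together or to only one of them. Also open, from the compounds shown here alone, is how a phenyl ring carrying one methoxy group, an amine or a carboxylic acid would read here.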